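Swapping a sulfonamide for a pyridine on the shared core

The compounds below may be only part of what the source reports. "The series", "measured", "known", "first", "only" and "open" are said of these compounds alone.

Compound 1 `CCCS(=O)(=O)Nc1cccc2c1CCC2c1ncc[nH]1` is the weakest of the three compounds measured in a functional assay on CHO cells for agonist activity at Alpha-1A adrenergic receptor (Homo sapiens), read by FLIPR and calcium flux (a lower number here means that less compound is needed, a higher number that more compound is needed for the effect), where compound 1 gives 1340 nM. Compound 2 `CCS(=O)(=O)Nc1cccc2c1CCC2c1ncc[nH]1` gives 32 nM in this assay, and compound 3 `c1ccc2c(c1)CCCC2c1ncc[nH]1`, which carries no group at all on its aromatic ring and has a different core, gives 385 nM.

Compound 4 `c1cncc(-c2cccc3c2CCC3c2ncc[nH]2)c1` differs from compound 1 in one place: pyridin-3-yl in place of (propylsulfonyl)amino on an aromatic carbon. Within the data shown here, no measured step makes this same change. Among the measured compounds shown here, the only measured step, from compound 1 to compound 2, shortens the chain on the sulfonyl group and gives a 42-fold lower number from compound 1 to compound 2 (1.62 log units; beyond the scatter), which shows that this part of the molecule is sensitive to change. For the measured compounds named here, compound 3 shows only that the core without any group here sits between compound 1 and compound 2 in this assay.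

Going by the values given here, with no step that bears directly on the change, the direction is uncertain, though the large step from compound 1 to compound 2 suggests that a moderate change is more likely than none. Compound 4 is therefore expected to give 500 nM in this assay, within a wide range from 80 nM to 3000 nM, which amounts to an estimated step of a 2.7-fold lower number from compound 1 to compound 4 (0.43 log units; beyond the scatter).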

Compound 4, half-maximal effective concentration: 2060 nM
Compound 4: middle estimate off by 4.1-fold (0.61 log units), on the low side, and the stated range covers the measured number.
By their numbers in this assay, from the lowest: compound 2; then compound 3; then compounds 1 and 4 (each within the scatter of the next).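

In this assay, the step from the (propylsulfonyl)amino group to pyridin-3-yl on this aromatic carbon is a 1.5-fold higher number from compound 1 to compound 4 (0.19 log units; within the scatter) and so leaves the two compounds indistinguishable, even though a chain with no ring and a hydrogen-bond donor gives way to an aromatic ring with no such donor. The same replacement starting from the (ethylsulfonyl)amino group is a 64-fold higher number from compound 2 to compound 4 (1.81 log units; beyond the scatter) and is large, so the low number of compound 2 does not carry over to pyridin-3-yl, and the size of this change depends on which sulfonyl chain it starts from. No independent measurement is available to explain why these two steps differ so much.

A plain amine or a (methylsulfonyl)amino group on the same aromatic carbon would help to show whether the low number of compound 2 depends on the sulfonyl group itself or on the length of the chain attached to it. A phenyl group in the same place would test whether the ring nitrogen of pyridin-3-yl matters at all to the number in this assay for this shared core.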